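The source may report more compounds than this note shows. Statements on the series, on what has been measured and on what is new or still open speak of the compounds shown alone.

Measured so far in a functional assay on the whole organism for inhibition, with Rattus norvegicus as the target, read by cytopathic effect and paw edema, at a dose of 100 mg/kg by the oral route; a higher number here means more inhibition at the dose given (going by the name of the read-out), a lower number less inhibition:
compound 1 `O=C(NCc1ccccc1)c1c(O)c2cccnc2n(-c2ccccc2)c1=O` gives 11.3%
compound 2 `O=C(Nc1cccc([N+](=O)[O-])c1)c1c(O)c2cccnc2n(-c2ccccc2)c1=O` gives 7.4%

Compound 2 stands lowest of the two numbers in this assay; its nearest neighbour is compound 1, whose number is higher by a step that lies within the scatter. For the measured compounds named here, the single step measured so far, a number 3.9 percentage points lower from compound 1 to compound 2 (within the scatter), exchanges the group on the amide-type nitrogen and leaves the read-out within the scatter.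

Compound 3 `Cc1cnccc1NC(=O)c1c(O)c2cccnc2n(-c2ccccc2)c1=O` is not yet measured. Its change from compound 2 is 3-methylpyridin-4-yl in place of 3-nitrophenyl on an amide-type nitrogen. Going by the values given here, the only step that bears on it, a number 3.9 percentage points lower from compound 1 to compound 2 (within the scatter), concerns the same amide-type nitrogen and was within the scatter; no measured pair shows a six-membered aromatic ring with 1 hetero atom in this place, so nothing in the numbers so far points to a step beyond the scatter in either direction in this assay. The step is therefore expected to be a number 2.6 percentage points higher from compound 2 to compound 3 (within the scatter), within the scatter. For compound 3 in this assay the expected value is 10%, with a range from 0% to 25%.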

Compound 3, a percentage reported as inhibition, in the whole organism at one dose (the size of the read-out at that dose, not a potency): 8.8%
For compound 3 the middle estimate is 1.2 percentage points above the measured one, and the stated range covers the measured number.
By their numbers in this assay, from the lowest: compounds 2, 3 and 1 (each within the scatter of the next).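

On the amide-type nitrogen in this assay, 3-methylpyridin-4-yl in place of 3-nitrophenyl gives a number 1.4 percentage points higher from compound 2 to compound 3 (within the scatter), so this position now carries a six-membered aromatic ring with 1 hetero atom, and neither that ring nor the removal of the nitro group separates the two compounds. Set against the benzyl amide, the same group gives a number 2.5 percentage points lower from compound 1 to compound 3 (within the scatter), so benzyl, 3-nitrophenyl and 3-methylpyridin-4-yl all stand within the scatter of one another, and this holds for a carbon-only aromatic ring with or without a methylene link and for the ring with 1 hetero atom. No supporting measurement bears on this result, so the flat reading stays a plain observation on these three compounds.

On these data alone, it remains open whether a group of a different kind on this nitrogen, such as a longer alkyl chain, a chain ending in an amine or a phenyl ring carrying a carboxylic acid, would produce a step beyond the scatter in this assay. Also open, as far as these compounds go, is whether changes elsewhere on the shared core would move the read-out more than changes at this amide do.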